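The source may report more compounds than this note shows. Statements on the series, on what has been measured and on what is new or still open speak of the compounds shown alone.

In a functional assay on HepG2 cells (Homo sapiens) for inhibition, read by MTT assay, with a stated time of 72 h (on this read-out higher numbers stand for weaker inhibition and lower numbers for stronger inhibition), compound 1 `COc1ccc(-c2cc(C(=O)N3CCC4(CC3)CC(=O)c3nn(C(C)(C)C)cc3O4)c3ccccc3n2)cc1OC` gives 1560 nM and compound 2 `CC(C)(C)n1cc2c(n1)C(=O)CC1(CCN(C(=O)c3cc(-c4ccccn4)nc4ccccc34)CC1)O2` gives 1500 nM, so compound 2 stands level with compound 1 within the usual scatter. Going by the values given here, the only measured step is a 1.0-fold lower number from compound 1 to compound 2 (0.02 log units; within the scatter), which puts pyridin-2-yl in place of 3,4-dimethoxyphenyl on an aromatic carbon. Compound 3 `Cc1cc(C(=O)N2CCC3(CC2)CC(=O)c2nn(C(C)(C)C)cc2O3)c2ccccc2n1` changes that same carbon again, with methyl in place of pyridin-2-yl on an aromatic carbon. Among the compounds with values here, the measured step shows that two different ring-bearing groups there give numbers within the scatter, but no measured compound carries a methyl at this carbon, so it offers only loose guidance. A modest move towards a higher number in this assay is therefore expected, and the range is kept wide. The estimated change is a 2.0-fold higher number from compound 2 to compound 3 (0.30 log units; within the scatter). For compound 3 the expected value is 3000 nM, with an estimated range of 1000 nM to 10000 nM.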

Compound 3, half-maximal inhibitory concentration: 9480 nM
Estimate against measurement, compound 3: 3.2-fold (0.50 log units) below; the measured number falls inside the stated range.
By their numbers in this assay, from the lowest: compounds 2 and 1 (each within the scatter of the next); then compound 3.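

In this assay the aromatic carbon next to the ring nitrogen proves sensitive to what it carries: methyl in place of pyridin-2-yl gives a 6.3-fold higher number from compound 2 to compound 3 (0.80 log units; beyond the scatter) and methyl in place of 3,4-dimethoxyphenyl gives a 6.1-fold higher number from compound 1 to compound 3 (0.78 log units; beyond the scatter) and both steps lie beyond the scatter. Going by these compounds alone, the two ring-bearing groups gave numbers level with each other, so their differences did not show this sensitivity, whereas methyl, the one group here with no ring, gives the weakest inhibition of the three compounds. Nothing available explains why the number rises when the ring is lost.

The compounds shown leave open whether an aromatic ring is needed at this carbon or whether any group larger than methyl would serve. A saturated ring such as cyclohexyl or a longer chain such as butyl at this carbon would help separate these two readings.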